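This account rests on a few compounds, and the source may have more. Where it says the series, first, only, none or still open, it means among the compounds named here.

Compound 1 `COc1ccc(-c2ssc(=S)c2-c2cc(OC)c(OC)c(OC)c2)cc1O`: 271 nM
Compound 2 `COc1ccc(-c2c(-c3cc(OC)c(OC)c(OC)c3)ssc2=S)cc1`: 2350 nM
Compound 3 `COc1ccc(-c2ssc(=O)c2-c2cc(OC)c(OC)c(OC)c2)cc1`: 134 nM

All three compounds were tested in a functional assay on SGC-7901 cells (Homo sapiens) for antiproliferative activity, read by MTT assay, with a stated time of 72 h; a lower number here means a stronger inhibitor, a higher number a weaker inhibitor. Among them, compound 3 gives the lowest number, 134 nM. The nearest neighbour is compound 1 at 271 nM, and furthest away lies compound 2 at 2350 nM. Both gaps lie beyond the usual scatter.

The next compound to be tested is compound 4 `COc1ccc(-c2ssc(=O)c2-c2cc(OC)c(OC)c(OC)c2)cc1N`. It keeps everything in compound 3 except for one change, amino in place of hydrogen on an aromatic carbon, so that 4-methoxyphenyl becomes 3-amino-4-methoxyphenyl.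

Among the measured compounds shown here, no two measured compounds differ in only one place, so the data offer no direct guide to this step. The closest hint is indirect. Compound 1, at 271 nM, carries a hydroxy group on its methoxyphenyl group and has a lower number than compound 2, at 2350 nM, which lacks that group, though the two differ in other ways too. On that slender evidence, the expected change is a 3.4-fold lower number from compound 3 to compound 4 (0.53 log units; beyond the scatter), towards a stronger inhibitor and modestly beyond the scatter. The estimated value for compound 4 is 40 nM, with an expected range from 8 nM to 200 nM.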

Compound 4, half-maximal inhibitory concentration: 172 nM
Compound 4: middle estimate off by 4.3-fold (0.63 log units), on the low side, and the stated range covers the measured number.
By their numbers in this assay, from the lowest: compounds 3, 4 and 1 (each within the scatter of the next, the first and the last beyond it); then compound 2.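

In this assay, placing amino in place of hydrogen on an aromatic carbon, which turns 4-methoxyphenyl into 3-amino-4-methoxyphenyl, gives a 1.3-fold higher number from compound 3 to compound 4 (0.11 log units; within the scatter) and so leaves the two compounds indistinguishable. Among the compounds shown here, this is the first direct reading of this position, as no earlier pair differed in only one place, and it shows that an aromatic carbon ortho to a methoxy group can carry an amino group with no change that this assay can resolve. No measurement available here bears on why the step is so small.

With only hydrogen and amino shown at this position, it remains open whether a larger or differently built group, such as a dimethylamino group, an acetamide or a fluorine atom, would also leave the number within the scatter or would move it clearly in either direction. As far as these compounds go, it also remains open whether the same amino group would give so small a step on the core of compound 1 or compound 2, or in a cell line other than the one used here.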